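This account rests on a few compounds, and the source may have more. Where it says the series, first, only, none or still open, it means among the compounds named here.

Compound 1 `COc1nc2ccccc2cc1/C=C/c1noc(-c2ccccc2)n1`, compound 2 `COc1ccccc1-c1nc(/C=C/c2cc3ccccc3nc2OC)no1` and compound 3 `COc1nc2ccccc2cc1/C=C/c1noc(-c2ccccc2Br)n1` share one core and differ on the phenyl ring. In an ADME assay on HepG2 cells (Homo sapiens) for cytotoxicity, read by sulforhodamine B assay, with a stated time of 48 h (a higher number here means that more compound is tolerated, a lower number that less compound is tolerated), compound 1 reaches only the limit > 240000 nM. Compound 2 likewise gives only the limit > 220000 nM. Compound 3 also stops at the limit > 195000 nM. So compound 2 stands at a limit among limits, and the steps a step that the two limits leave unreadable from compound 1 to compound 2, a step that the two limits leave unreadable from compound 1 to compound 3 and a step that the two limits leave unreadable from compound 2 to compound 3 carry no readable size. Compound 4 `COc1nc2ccccc2cc1/C=C/c1noc(-c2cccnc2)n1` differs from compound 2 as pyridin-3-yl in place of 2-methoxyphenyl on an aromatic carbon. Going by the values given here, no measured step gives a size for a change at this position, so in this assay the step of an at least 1.1-fold lower number from compound 2 to compound 4 (0.04 log units; that floor lies within the scatter) is expected to stay within the scatter. For compound 4 the estimate is 200000 nM, between 60000 nM and 300000 nM.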

Compound 4, half-maximal cytotoxic concentration: > 240000 nM
Compound 4 ended at the assay's limit; the forecaster's own chance of this, stated with the estimate: 75%; middle value at least 1.2-fold (0.07 log units) away from the limit.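

Compound 4 gives only the limit > 240000 nM. Its steps from compounds 1, 2 and 3 cannot be read, as all four values are limits. The compounds shown leave open the concentration at which any of them becomes cytotoxic.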